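Nitro for Methyl on Two Cores in a Seizure Model

This account rests on a few compounds, and the source may have more. Where it says the series, first, only, none or still open, it means among the compounds named here.

The measured compounds are:
Compound 1 `Cc1ccc2nc(NC(=O)/C=C/OC3=CC=C3)sc2c1` with 505 umol/kg in a functional assay on the whole organism (Hindlimb, strain albino) with Mus musculus as the target, in the maximal electroshock model, with a stated time of 0.5 h; a higher number here means that more compound is needed for the effect, a lower number that less compound is needed;
compound 2 `O=C(/C=C/OC1=CC=C1)Nc1nc2ccc([N+](=O)[O-])cc2s1` with 597 umol/kg in this assay;
compound 3 `COc1ccc(C2CC(Nc3nc4ccc(C)cc4s3)=NN2C(C)=O)cc1O` with 73.9 umol/kg in this assay.

Compound 1 and compound 2 share one core and differ by nitro in place of methyl on an aromatic carbon. The step is a 1.2-fold higher number from compound 1 to compound 2 (0.07 log units; within the scatter); the two values thus lie within the scatter of each other and show no order.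

Compound 3 carries a different core; the difference between the two cores is not broken down here. In this assay compound 3 gives the lowest number of the three, and its steps to compound 1 and to compound 2 are beyond the scatter.

Compound 4 `COc1ccc(C2CC(Nc3nc4ccc([N+](=O)[O-])cc4s3)=NN2C(C)=O)cc1O` is not yet measured. It stands to compound 3 as compound 2 stands to compound 1: the change is nitro in place of methyl on an aromatic carbon, the same change at the same kind of place. Because the earlier step was a 1.2-fold higher number from compound 1 to compound 2 (0.07 log units; within the scatter), the expected step here is a 1.2-fold higher number from compound 3 to compound 4 (0.08 log units; within the scatter), resting on that single precedent on another core. Compound 4 is therefore estimated at 88 umol/kg, between 40 umol/kg and 200 umol/kg.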

Compound 4, dose for half-maximal effect: 178 umol/kg
Beside the measured number, compound 4's estimate is 2.0-fold (0.31 log units) below it, within the range that was stated.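

In this assay, nitro in place of methyl on the core of compound 3 gives a 2.4-fold higher number from compound 3 to compound 4 (0.38 log units; beyond the scatter), a modest step. Set beside the earlier step on the other core, the two cannot be told apart, so in this series the change carries over from one core to the other without a measurable difference: the same change on two cores in this assay, a 1.2-fold higher number (0.07 log units; within the scatter) from compound 1 to compound 2 and a 2.4-fold higher number (0.38 log units; beyond the scatter) from compound 3 to compound 4, 2.0-fold (0.31 log units) apart, within the scatter of two such steps

Going by these compounds alone, this rests on only two pairs, and the step is beyond the scatter on one core but within it on the other, so it does not establish a general size for the change, nor does it explain the step on either core. The compounds shown leave open how other groups on the same aromatic carbon, such as an amine, a carboxylic acid or a longer alkyl chain, would read in this assay. They also leave open whether the nitro for methyl step would hold on a third core.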